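A small change carried from a small core to a larger one

The source may hold more compounds than are shown below. What is called first, only, known or untested is meant among the compounds shown, and "the series" means these compounds.

Compound 1, `Cc1cnn(C(=O)N2CCCCC2)c1`, measured in an assay on membranes from brain for binding affinity to Monoglyceride lipase (Mus musculus), read by fluorescence, with stated times of 1 h and 30 min (a higher number here means a weaker inhibitor, a lower number a stronger inhibitor), gives 9200 nM.
Compound 2, `O=C(N1CCCCC1)n1cccn1`, in this assay gives 6600 nM.
Compound 3, `Cc1cnn(C(=O)N2CCN(C(c3ccc(OCc4ccccc4)cc3)c3ccc(OCc4ccccc4)cc3)CC2)c1`, in this assay gives 2100 nM.

Compound 1 and compound 2 share a core and differ in one place: hydrogen in place of methyl on an aromatic carbon. That change gave a 1.4-fold lower number from compound 1 to compound 2 (0.14 log units; within the scatter), so the two values cannot be told apart. Compound 3 stands lowest of the three measured numbers; its nearest neighbour is compound 2, and compound 1 lies furthest away, both gaps beyond the scatter. The difference between the core of compound 3 and the core of compound 1 is not broken down here.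

Compound 4, `O=C(N1CCN(C(c2ccc(OCc3ccccc3)cc2)c2ccc(OCc3ccccc3)cc2)CC1)n1cccn1`, has not yet been measured in this assay. It is related to compound 3 by the change (hydrogen in place of methyl on an aromatic carbon). This is the same kind of change as that from compound 1 to compound 2; in the smaller pair the ring atom two ring bonds away bears a group of 8 heavy atoms, while in the larger pair it bears a large group. Because the earlier step was a 1.4-fold lower number from compound 1 to compound 2 (0.14 log units; within the scatter), the expectation for compound 4 is a step of about a 1.3-fold lower number from compound 3 to compound 4 (0.12 log units; within the scatter), again within the scatter. Compound 4 is therefore estimated at 1600 nM in this assay, expected to fall between 700 nM and 3500 nM.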

Compound 4, half-maximal inhibitory concentration: 3900 nM
The estimate for compound 4 lay 2.4-fold (0.39 log units) below the measured number; the measured number lies above the stated range.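

In this assay, replacing the methyl with hydrogen on the larger core gave a 1.9-fold higher number from compound 3 to compound 4 (0.27 log units; within the scatter), so the two values cannot be told apart, and the same holds for the two values on the smaller core. Set side by side, the two steps do not differ from each other: the same change on two cores in this assay, a 1.4-fold lower number (0.14 log units; within the scatter) from compound 1 to compound 2 and a 1.9-fold higher number (0.27 log units; within the scatter) from compound 3 to compound 4, 2.6-fold (0.41 log units) apart, within the scatter of two such steps. This shows that, on the two cores seen here, going from 4-methyl-1H-pyrazol-1-yl to 1H-pyrazol-1-yl left the number unresolved from the usual scatter, and that nothing in these two pairs separates the behaviour of the change on one core from its behaviour on the other; it does not show that the change has no effect at all, since a small real step could hide inside that scatter, and two pairs say nothing about any further core.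

The compounds shown leave open what a different group on that aromatic carbon of the five-membered ring would do, for instance an ethyl group, a chlorine atom, a nitrile or a carboxylic acid. They also leave open whether such a replacement would give a step that could be read on both cores, and whether the two steps would then agree.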